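The source may hold more compounds than are shown below. What is called first, only, known or untested is meant among the compounds shown, and "the series" means these compounds.

Compound 1 `CC1(OC(=O)N2C[C@H]3COC[C@@H](C2)[C@@H]3Oc2ncnc(Nc3ccc(C#N)cc3Cl)c2F)CC1` belongs to a small set of three compounds that share one core and differ only in the substituted phenyl ring carried on the nitrogen attached to that core. In a functional assay on HEK293 cells for agonist activity at Glucose-dependent insulinotropic receptor (Homo sapiens), read by cAMP accumulation, with a stated time of 30 min (on this read-out lower numbers stand for an effect already at smaller amounts and higher numbers for an effect only at larger amounts of compound), compound 1 gives 10 nM. Compound 3 `CC1(OC(=O)N2CC3COCC(C2)C3Oc2ncnc(Nc3ccc(C#N)cc3Cl)c2F)CCC1` gives 10 nM in this assay, the same number as compound 1 at the digits shown, and the two together stand at the lowest numbers of the set. Compound 2 `CC1(OC(=O)N2CC3COCC(C2)C3Oc2ncnc(Nc3ccc(F)cc3F)c2F)CC1`, whose phenyl ring bears two fluorine atoms, gives 15 nM in this assay, a gap from compound 1 that lies within the scatter of repeated measurements.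

Compound 4 `CC1(OC(=O)N2C[C@H]3COC[C@@H](C2)[C@@H]3Oc2ncnc(Nc3c(F)cccc3F)c2F)CC1` has not yet been measured. It differs from compound 1 by a single change: 2,6-difluorophenyl in place of 2-chloro-4-cyanophenyl on a nitrogen on an aromatic ring. Going by the values given here, no pair of measured compounds isolates this exact change, so the size of the step cannot be read off. Among the compounds with values here, the only guide is that compound 2, also with a phenyl ring bearing two fluorine atoms, gives 15 nM, close to compound 1 at 10 nM. On that basis only a modest step is expected, a 2.5-fold higher number from compound 1 to compound 4 (0.40 log units; beyond the scatter), in the direction of a somewhat higher number. Compound 4 is expected to give about 25 nM in this assay, with a range from 8 nM to 80 nM.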

Compound 4, half-maximal effective concentration: 13 nM
Compound 4: the middle estimate sits 1.9-fold (0.28 log units) above what was measured; measured number inside the range.
By their numbers in this assay, from the lowest: compounds 1, 3, 4 and 2 (each within the scatter of the next).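

In this assay, going by these compounds alone, 2,6-difluorophenyl in place of 2-chloro-4-cyanophenyl on a nitrogen on an aromatic ring gives a 1.3-fold higher number from compound 1 to compound 4 (0.11 log units; within the scatter), the first step in this set that can be read directly. On this read-out, the phenyl ring at this position can therefore give up both its nitrile and its chlorine for two fluorine atoms, and the result cannot be told apart from the scatter of repeated measurements. Nothing shown here explains why these two rings give such similar numbers.

Going by these compounds, it remains open whether the ring needs any substituent at all, which plain phenyl would test, and whether a methoxy group or a carboxylic acid on the ring would give a similar number. On these data alone, it is also open whether the ring must be aromatic, a question that cyclohexyl on the same nitrogen would address.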